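From hydroxy to methoxymethoxy on compound 2

The compounds below may be only part of what the source reports. "The series", "measured", "known", "first", "only" and "open" are said of these compounds alone.

Among the measured compounds shown here, in a functional assay on J774.A1 cells (Mus musculus) for inhibition, read by Griess assay, with stated times of 1 h and 24 h (on this read-out higher numbers stand for weaker inhibition and lower numbers for stronger inhibition), compound 1 (`CCCOc1ccccc1C1CC(=O)c2ccccc2O1`) gives 44600 nM and compound 2 (`O=C1CC(c2ccccc2O)Oc2ccccc21`) gives 71300 nM, so compound 2 stands within the scatter of the only other number available. Compound 3 (`COCOc1ccccc1C1CC(=O)c2ccccc2O1`) carries methoxymethyl in place of hydrogen on an oxygen on an aromatic ring. For the measured compounds named here, the one measured step of this kind, hydrogen in place of propyl, is a 1.6-fold higher number from compound 1 to compound 2 (0.20 log units; within the scatter), so no shift beyond the scatter is expected in this assay. The expected change is a 1.4-fold lower number from compound 2 to compound 3 (0.14 log units; within the scatter). For compound 3 the estimated value is 52000 nM, with an expected range of 25000 nM to 105000 nM.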

Compound 3, half-maximal inhibitory concentration: 35200 nM
Beside the measured number, compound 3's estimate is 1.5-fold (0.17 log units) above it, and the stated range covers the measured number.
By their numbers in this assay, from the lowest: compounds 3, 1 and 2 (each within the scatter of the next, the first and the last beyond it).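

In this assay, among the compounds shown here, methoxymethyl on this oxygen gives a 2.0-fold lower number from compound 2 to compound 3 (0.31 log units; beyond the scatter) and so provides the first step here that lies beyond the scatter, though only modestly. Between the two groups that cover this oxygen, the change gives a 1.3-fold lower number from compound 1 to compound 3 (0.10 log units; within the scatter) and stays within the scatter, so methoxy in place of ethyl at the end of the chain cannot be told apart in this read-out. Nothing available explains either step. Going by these compounds, what remains open is whether a longer chain, an amine or a carboxylic acid on this oxygen would move the number further.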